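Aryl swaps on the shared core: compound 3 to compound 4

The source may hold more compounds than are shown below. What is called first, only, known or untested is meant among the compounds shown, and "the series" means these compounds.

Measured so far:
- In a functional assay on K562 cells (Homo sapiens), read by MTT assay, with a stated time of 72 h (a lower number here means a stronger inhibitor, a higher number a weaker inhibitor), compound 1 `O=c1[nH]cnc2c1c(-c1ccoc1)cn2[C@@H]1O[C@H](CO)[C@@H](O)[C@H]1O` gives 14500 nM.
- Compound 2 `O=c1[nH]cnc2c1c(-c1cccs1)cn2[C@@H]1O[C@H](CO)[C@@H](O)[C@H]1O` reaches only the limit of this assay, > 20000 nM, and no number.
- Compound 3 `O=c1[nH]cnc2c1c(-c1ccco1)cn2[C@@H]1O[C@H](CO)[C@@H](O)[C@H]1O` gives 17800 nM in this assay.

Compound 3 holds the highest of the two numbers in this assay, though its nearest neighbour, compound 1, sits within the scatter: a 1.2-fold higher number from compound 1 to compound 3 (0.09 log units; within the scatter). Against compound 2 the comparison rests on a limit, an at least 1.1-fold lower number from compound 2 to compound 3 (0.05 log units; that floor lies within the scatter), and that floor too lies within the scatter; the limit itself is the limit of > 20000 nM in this assay, at which 1 of the 3 values shown sits.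

Compound 4 `O=c1[nH]cnc2c1c(-c1ccccc1)cn2[C@@H]1O[C@H](CO)[C@@H](O)[C@H]1O` differs from compound 3 by phenyl in place of furan-2-yl on an aromatic carbon. Among the measured compounds shown here, the steps that bear on this are the aryl exchanges already seen on the same carbon: an at least 1.3-fold higher number from compound 1 to compound 2 (0.13 log units; that floor lies within the scatter) and a 1.2-fold higher number from compound 1 to compound 3 (0.09 log units; within the scatter). None of them moved this assay beyond the scatter, so no step beyond the scatter is expected here either, in either direction. Compound 4 is therefore estimated at 17000 nM in this assay, with a range from 7000 nM to 40000 nM. The expected step is a 1.0-fold lower number from compound 3 to compound 4 (0.02 log units; within the scatter).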

Compound 4, half-maximal inhibitory concentration: > 20000 nM
Compound 4 gave a limit, no number (the forecaster's own chance of this, stated with the estimate: 30%); at least 1.1-fold (0.07 log units) between middle value and limit.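

Phenyl is the first group on this aromatic carbon that is a six-membered aromatic ring of carbon only, and in this assay the change of ring size separates it from neither furan: an at least 1.1-fold higher number from compound 3 to compound 4 (0.05 log units; that floor lies within the scatter) and an at least 1.3-fold higher number from compound 1 to compound 4 (0.13 log units; that floor lies within the scatter). Neither of these floors establishes a step beyond the scatter, and the step between compound 2 and compound 4 cannot be read, as both values are limits. The thiophen-2-yl and phenyl compounds now share the same limit, so the read-out gives no order among them: the limit of > 20000 nM in this assay, at which 2 of the 4 values shown sit.

Going by these compounds, it remains open how far compound 2 and compound 4 lie past that limit. Also open, on these data alone, is whether an amine, a carboxylic acid or a longer chain on this carbon, in place of an aromatic ring, would move the number beyond the scatter.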